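Three benzyl variants, all without measurable cytotoxicity

The source may hold more compounds than are shown below. What is called first, only, known or untested is meant among the compounds shown, and "the series" means these compounds.

Compound 1 `CCOC(=O)c1cnc(N2CCN(Cc3cccc(C(F)(F)F)c3)CC2)nc1Oc1c(C)cc(-c2ccc(C#N)cc2)cc1C` was examined in an ADME assay on MT4 cells (Homo sapiens) for cytotoxicity, read by MTT assay, with a stated time of 4 days; on this read-out lower numbers stand for higher toxicity in this test and higher numbers for lower toxicity in this test. Compound 1 gives > 125000 nM, which is a limit of the assay and not a number. Compound 2 `CCOC(=O)c1cnc(N2CCN(Cc3ccccc3F)CC2)nc1Oc1c(C)cc(-c2ccc(C#N)cc2)cc1C` gives > 125000 nM, likewise a limit. Compound 3 `CCOC(=O)c1cnc(N2CCN(Cc3cccc(Br)c3)CC2)nc1Oc1c(C)cc(-c2ccc(C#N)cc2)cc1C` gives > 125000 nM, again a limit. Among these three, the moves are a step that the two limits leave unreadable from compound 1 to compound 2 and a step that the two limits leave unreadable from compound 1 to compound 3, and a step that the two limits leave unreadable from compound 2 to compound 3 stands the same way; the whole picture is the limit of > 125000 nM in this assay, at which 3 of the 3 values shown sit, so no direction or size can be read from any of them.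

Compound 4 `CCOC(=O)c1cnc(N2CCN(Cc3cc(F)cc(F)c3)CC2)nc1Oc1c(C)cc(-c2ccc(C#N)cc2)cc1C` is the next member of the series, and its change from compound 1 is 3,5-difluorophenyl in place of 3-(trifluoromethyl)phenyl on a saturated chain carbon bound to an amine nitrogen in a ring. Among the measured compounds shown here, the three measured steps bear on it only in the sense that every benzyl variation so far has stayed at the limit, so no step beyond the scatter is expected in this assay. Compound 4 is therefore expected to give 150000 nM, with a range from 60000 nM to 400000 nM. The expected change, a step that the limit leaves unreadable from compound 1 to compound 4, is estimated to be essentially none.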

Compound 4, half-maximal cytotoxic concentration: > 125000 nM
Compound 4 was reported as a limit (the forecaster's own chance of this, stated with the estimate: 90%); the middle value is on the limit's open side.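

Compound 4 gives > 125000 nM in this assay, again a limit and not a number. Its steps to compound 1, compound 2 and compound 3 therefore cannot be read: the limit of > 125000 nM in this assay, at which 4 of the 4 values shown sit. The compounds shown leave open whether any of these benzyl changes alters cytotoxicity at all, and where the true values lie beyond the limit.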